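The compounds below may be only part of what the source reports. "The series", "measured", "known", "first", "only" and "open" are said of these compounds alone.

Of the compounds shown here, three sharing one core have been measured in a functional assay on MCF7 cells (Homo sapiens) for cytotoxicity, read by MTT assay, with a stated time of 48 h; a higher number here means a weaker inhibitor, a lower number a stronger inhibitor. Compound 1 `COc1ccc(N/C(CCNC2=CC(=O)c3ccccc3C2=O)=N\S(=O)(=O)c2ccc(C)cc2)cc1` gives 6030 nM, compound 2 `Cc1ccc(S(=O)(=O)/N=C(/CCNC2=CC(=O)c3ccccc3C2=O)Nc2ccc(Cl)cc2)cc1` gives 7080 nM, and compound 3 `Cc1ccc(S(=O)(=O)/N=C(/CCNC2=CC(=O)c3ccccc3C2=O)Nc2ccccc2I)cc1` gives 15500 nM. Compound 3 therefore stands at the highest number of the three: the step of a 2.6-fold higher number from compound 1 to compound 3 (0.41 log units; beyond the scatter) and the step of a 2.2-fold higher number from compound 2 to compound 3 (0.34 log units; beyond the scatter) both lie beyond the scatter, whereas the step of a 1.2-fold higher number from compound 1 to compound 2 (0.07 log units; within the scatter) does not.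

Compound 4 `Cc1ccc(S(=O)(=O)/N=C(/CCNC2=CC(=O)c3ccccc3C2=O)Nc2cc(F)c(F)c(F)c2)cc1` differs from compound 3 in one place: 3,4,5-trifluorophenyl in place of 2-iodophenyl on an amine nitrogen. Going by the values given here, no measured pair shows exactly this exchange. The steps that come nearest are those leading to compound 3 from compound 1 and from compound 2, where a 2-iodophenyl replaced a 4-methoxyphenyl or a 4-chlorophenyl on the same amine nitrogen and the number rose modestly in both cases. Compound 4 removes the 2-iodophenyl again and brings in a 3,4,5-trifluorophenyl, a group not seen among the measured compounds, so the direction can only be guessed from the fact that the two other aryl groups gave lower numbers than compound 3 did. The expected step is thus a modest drop, a 1.9-fold lower number from compound 3 to compound 4 (0.29 log units; within the scatter), with wide uncertainty. Compound 4 is estimated at 8000 nM, within a range from 3000 nM to 25000 nM.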

Compound 4, half-maximal inhibitory concentration: 6610 nM
Compound 4: the middle estimate sits 1.2-fold (0.08 log units) above what was measured, and the stated range covers the measured number.
By their numbers in this assay, from the lowest: compounds 1, 4 and 2 (each within the scatter of the next); then compound 3.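

In this assay, going by these compounds alone, putting 3,4,5-trifluorophenyl in place of 2-iodophenyl on the amine nitrogen gives a 2.3-fold lower number from compound 3 to compound 4 (0.37 log units; beyond the scatter), so a third aryl group now lies clear of compound 3, which until now had only two aryl groups to be set against. The new group does not separate from those two, with a 1.1-fold lower number from compound 2 to compound 4 (0.03 log units; within the scatter) and a 1.1-fold higher number from compound 1 to compound 4 (0.04 log units; within the scatter), so among the four compounds the 4-methoxyphenyl, 4-chlorophenyl and 3,4,5-trifluorophenyl groups fall together and only the 2-iodophenyl of compound 3 stands apart, even though the three differ in what they carry on the ring. Nothing available here accounts for this separation of compound 3 from the others.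

On these data alone, whether the higher number of compound 3 goes with the iodine itself or with where it sits on the ring stays open, and so does how a plain phenyl, a benzyl or a cyclohexyl group on the same nitrogen would compare. The compounds shown also leave open how the number responds to changes away from this nitrogen, such as a longer chain in the linker or an amine on the 4-methylphenyl of the sulfonyl group.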